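Carboxymethoxy in Place of Propyl on Compound 3

The compounds below may be only part of what the source reports. "The series", "measured", "known", "first", "only" and "open" are said of these compounds alone.

In an in vitro ADME assay on microsomes from liver (Homo sapiens) for metabolic stability (on this read-out higher numbers stand for fast clearance and lower numbers for slow clearance), compound 3 `CCCCc1nnc(C2CCN(c3ccccn3)CC2)n1Cc1ccccc1` stands highest of the measured compounds at 154 mL.min-1.g-1 and is the starting point here. Its nearest neighbour, compound 2 `Cc1nnc(C2CCN(c3ccccn3)CC2)n1Cc1cccc(Cl)c1`, gives 29 mL.min-1.g-1 on the same scale, a gap beyond the scatter. Compound 1 `Cc1nnc(C2CCN(c3ccccn3)CC2)n1-c1ccccc1` reads < 8 mL.min-1.g-1 in this assay and that figure is a limit of the assay, not a number.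

Compound 4 `O=C(O)COCc1nnc(C2CCN(c3ccccn3)CC2)n1Cc1ccccc1` carries carboxymethoxy in place of propyl on a saturated chain carbon bound to an aromatic carbon and is otherwise the same as compound 3. Among the compounds with values here, the only measured single change is an at least 3.6-fold higher number from compound 1 to compound 2 (0.55 log units; beyond the scatter) and it lies on an aromatic nitrogen, so it bears on this chain only indirectly. It shows that one change can move the number beyond the scatter. Compound 3 at 154 mL.min-1.g-1 leaves ample room for a fall. The expected change is a 15-fold lower number from compound 3 to compound 4 (1.19 log units; beyond the scatter) and it points to a lower number, well beyond the scatter. Compound 4 is estimated at 10 mL.min-1.g-1 with an expected range from 4 mL.min-1.g-1 to 30 mL.min-1.g-1 and a real chance of reading only a limit.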

Compound 4, intrinsic clearance in microsomes: < 8 mL.min-1.g-1
Compound 4: no number, only a limit; the forecaster's own chance of this, stated with the estimate: 55%; at least 1.2-fold (0.09 log units) between middle value and limit.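

In this assay, within the data shown here, carboxymethoxy in place of propyl on a saturated chain carbon bound to an aromatic carbon gives an at least 19-fold lower number from compound 3 to compound 4 (1.28 log units; beyond the scatter), so a single change at this place, which no earlier step touched, can move the read-out by a large step. Compound 4 gives < 8 mL.min-1.g-1, which is a limit of the assay and not a number, so the step has a known minimum size but no known full size. Two different compounds now sit at that limit: the limit of < 8 mL.min-1.g-1 in this assay, at which 2 of the 4 values shown sit.

The compounds shown leave open which part of carboxymethoxy carries the step, as the carboxylic acid and the ether oxygen enter together. From the compounds shown here alone, a methyl ester, a plain ether chain or an amine on this carbon would separate these parts, and the true clearance of compound 4 also stays open.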